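Azetidinyl for dimethylamino on the hexadecyl pyridinol core

A few compounds are considered here, and "the series" means these few. Any claim that something is new, unique, unknown or untested is made for them only; others in the source may bear on it.

Compound 1 `CCCCCCCCCCCCCCCCc1c(C)c(N(C)C)nc(C)c1O` heads the three numbers in hand. In a functional assay on cells (Lymphocyte, Homo sapiens) for inhibition, read by flow cytometry, using a membrane potential dye, with a stated time of 16 h, tested at 250 nM (on this read-out lower numbers stand for a weaker effect and higher numbers for a stronger effect at the one concentration tested), compound 1 gives 83%. Compound 2 `CCCCCCCCCCc1c(C)c(N(C)C)nc(C)c1O` gives 78%; the step of a number 5 percentage points lower from compound 1 to compound 2 (within the scatter) shows that shortening the chain by hydrogen in place of hexyl on a saturated chain carbon, ten or more bonds along the chain from an aromatic carbon, does not move the read-out. Going by the values given here, compound 3 `CCCCCCCCCCCCCCCCc1nc(N2CCC2)c(C)c(C)c1O` gives 68%; it carries azetidin-1-yl on a differently substituted core, so its value stands on its own beside compound 1 and no step is drawn between them.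

Compound 4 `CCCCCCCCCCCCCCCCc1c(C)c(N2CCC2)nc(C)c1O` is the step (azetidin-1-yl in place of dimethylamino on an aromatic carbon). Among the compounds with values here, none of the measured steps touches this position, so no directly comparable size exists. Within the data shown here, the only azetidin-1-yl compound in hand, compound 3, sits below compound 1 on this read-out. Compound 4 is therefore expected to give 74%, between 60% and 86%, a step of a number 9 percentage points lower from compound 1 to compound 4 (within the scatter) that may be expected to fall within or just beyond the scatter.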

Compound 4, a percentage reported as activity, at one concentration (the size of the read-out at that concentration, not a potency): 72%
The estimate for compound 4 lay 2 percentage points above the measured number, and the stated range covers the measured number.
By their numbers in this assay, from the lowest: compounds 3, 4, 2 and 1 (each within the scatter of the next, the first and the last beyond it).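

In this assay the position next to the ring nitrogen now has a measured step of its own: azetidin-1-yl in place of dimethylamino gives a number 11 percentage points lower from compound 1 to compound 4 (beyond the scatter). The read-out therefore responds at this place to closing the amine into a four-membered ring, although the hydrogen-bond donor and acceptor counts stay the same, and the effect at the one concentration tested is reduced rather than lost. Nothing available explains the size of this step.

Going by these compounds, whether a pyrrolidin-1-yl or morpholin-4-yl group at this place would give a number closer to that of compound 1 remains open. Also open, on these data alone, is whether the azetidin-1-yl exchange would give a step of similar size on the shorter chain of compound 2.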